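The source may hold more compounds than are shown below. What is called first, only, known or untested is meant among the compounds shown, and "the series" means these compounds.

Compound 1 `CCOc1ccc(/C=C/C(=O)c2c(O)cc(C)oc2=O)cc1`: > 100000 nM (a limit)
Compound 2 `Cc1cc(O)c(C(=O)/C=C/c2ccc(-c3ccccc3)cc2)c(=O)o1`: > 100000 nM (a limit)

Both compounds were tested in a functional assay on HCT-116 cells (Homo sapiens) for cytotoxicity, read by MTT assay; on this read-out lower numbers stand for stronger inhibition and higher numbers for weaker inhibition. In this test compound 2 gives > 100000 nM, which is a limit and not a number. The only other result, for compound 1, is a limit too, so the whole picture so far is the limit of > 100000 nM in this assay, at which 2 of the 2 values shown sit.

Compound 3 `Cc1cc(O)c(C(=O)/C=C/c2ccc(N(C)C)cc2)c(=O)o1` keeps the shared core and changes one group, with dimethylamino in place of phenyl on an aromatic carbon.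

Within the data shown here, the one measured step that bears on this change is a step that the two limits leave unreadable from compound 1 to compound 2, which puts phenyl in place of ethoxy on an aromatic carbon. Its size cannot be read, so it offers no size or direction to carry over to the new change. The expectation therefore rests on compound 2 and its limit of > 100000 nM. A clear gain in this assay is not expected, and another limit is the likeliest report.

The step this implies is expected to be a number no higher from compound 2 to compound 3 (the limit leaves the size open). For compound 3 the estimate is 100000 nM, with an expected range from 40000 nM to 200000 nM.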

Compound 3, half-maximal inhibitory concentration: > 100000 nM
Compound 3: a limit, no number (the forecaster's own chance of this, stated with the estimate: 75%); the middle value sits exactly at the limit.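

In this assay compound 3 gives > 100000 nM, which is a limit and not a number. Among these compounds, since compound 1, compound 2 and compound 3 all give limits, no step between them can be read. The compounds shown leave open how these three differ in strength and whether any group at this place gives a measurable value: the limit of > 100000 nM in this assay, at which 3 of the 3 values shown sit.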